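Sulfonyl substituent variation: expectation for compound 4

This account rests on a few compounds, and the source may have more. Where it says the series, first, only, none or still open, it means among the compounds named here.

Measured in an assay on CHO cells for displacement of a labelled ligand from prostaglandin D2 receptor 2 (Homo sapiens), read by scintillation counting; on this read-out lower numbers stand for stronger inhibition and higher numbers for weaker inhibition:
compound 1 `Cc1ccc(S(=O)(=O)CCO)cc1C#Cc1cc(Cl)ccc1OCC(=O)O`, 19 nM
compound 2 `CNS(=O)(=O)c1ccc(C)c(C#Cc2cc(Cl)ccc2OCC(=O)O)c1`, 10 nM
compound 3 `Cc1ccc(S(=O)(=O)NC(C)(C)C)cc1C#Cc1cc(Cl)ccc1OCC(=O)O`, 5 nM

Compound 3 has the lowest number of the three, but the gap to compound 2 is within the scatter; only the gap to compound 1 is beyond it. Compound 4 `CCN(CC)S(=O)(=O)c1ccc(C)c(C#Cc2cc(Cl)ccc2OCC(=O)O)c1` differs from compound 3 by diethylamino in place of (tert-butyl)amino on a sulfonyl sulfur. The steps that touch the sulfonyl substituent are a 3.8-fold lower number from compound 1 to compound 3 (0.58 log units; beyond the scatter), a 2.0-fold lower number from compound 2 to compound 3 (0.30 log units; within the scatter) and a 1.9-fold lower number from compound 1 to compound 2 (0.28 log units; within the scatter); none of them exchanges a sulfonamide nitrogen bearing one hydrogen for one bearing none. Compound 1, which carries no sulfonamide nitrogen, gives the highest number of the three. On this basis a small rise in the number is expected for compound 4, a 2.0-fold higher number from compound 3 to compound 4 (0.30 log units; within the scatter), not clearly beyond the scatter. In this assay compound 4 is estimated at 10 nM, with a range from 4 nM to 30 nM.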

Compound 4, inhibition constant: 3.4 nM
Compound 4: middle estimate off by 2.9-fold (0.47 log units), on the high side; the whole stated range lies above it.
By their numbers in this assay, from the lowest: compounds 4, 3, 2 and 1 (each within the scatter of the next, the first and the last beyond it).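

In this assay the exchange for diethylamino, which has no hydrogen-bond donor, is a 1.5-fold lower number from compound 3 to compound 4 (0.17 log units; within the scatter) and so a hydrogen on the sulfonamide nitrogen is not required at this position. Diethylamino also gives a 2.9-fold lower number from compound 2 to compound 4 (0.47 log units; beyond the scatter) and a 5.6-fold lower number from compound 1 to compound 4 (0.75 log units; beyond the scatter) and thus stands clear of both methylamino and 2-hydroxyethyl on the sulfonyl sulfur. Nothing available explains these steps.

Open, on these data alone, is whether a longer chain such as dipropylamino, or a ring on the nitrogen such as pyrrolidine or morpholine, holds these numbers. As far as these compounds go, the unsubstituted amino group on the sulfonyl sulfur also remains open.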